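Acid for nitrile on the ether chain of compound 2

The source may report more compounds than this note shows. Statements on the series, on what has been measured and on what is new or still open speak of the compounds shown alone.

Three members of the series have numbers in an assay on isolated protein for inhibition of leukotriene B4 receptor 1 (Homo sapiens), tested at 10 uM; a lower number here means less inhibition, a higher number more inhibition at the concentration tested (going by the name of the read-out). Compound 1 `CC(=O)c1cc(CC2CO2)c(OCCCCC#N)cc1O` gives 62% in this assay. Compound 2 `CCc1cc(C(C)=O)c(O)cc1OCCCCCCCC(C)(C)C#N` gives 66% in this assay. Compound 3 `C=CCc1cc(C(C)=O)c(O)cc1OCCCC` gives 32% in this assay. Compound 2 carries the highest of the three numbers; compound 1 lies within the scatter of it, so no order between these two can be read, while compound 3 sits beyond the scatter on the low side.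

The next step leaves the core of compound 2 untouched and alters only the end of the ether chain: compound 4 `CCc1cc(C(C)=O)c(O)cc1OCCCCCCC(=O)O` is to be tested in this assay. The change is carboxy in place of 2-cyano-2-methylpropyl on a saturated chain carbon, six bonds along the chain from an oxygen on an aromatic ring. Going by the values given here, no measured pair shows this kind of exchange, so there is no step to lean on; the only anchor is the value of compound 2.

The expectation for compound 4 is a drop of moderate size, a number 21 percentage points lower from compound 2 to compound 4 (beyond the scatter), beyond the scatter but not to the floor. Compound 4 is thus estimated at 45%, within a range from 20% to 70%.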

Compound 4, a percentage reported as inhibition, at one concentration (the size of the read-out at that concentration, not a potency): 87%
For compound 4 the middle estimate is 42 percentage points below the measured one; measured number above the stated range.
By their numbers in this assay, from the lowest: compound 3; then compounds 1 and 2 (each within the scatter of the next); then compound 4.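

In this assay, carboxy in place of 2-cyano-2-methylpropyl gives a number 21 percentage points higher from compound 2 to compound 4 (beyond the scatter) and so shows that the nitrile and its branched end are not needed at this chain position for inhibition at the concentration tested. Going by these compounds alone, this is the first single-place step, and it shows that the number responds to what ends the ether chain. Nothing measured here accounts for the rise.

The exchange alters the end group's size and its functional group in one step, so the two cannot be separated from this pair alone. A methyl ester or primary amide at the same chain end, or a carboxylic acid on a longer chain, would bear on whether the free acid itself or the shorter chain end goes with the higher number.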